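Adding a methoxy group to the amide ring of compound 1

The compounds below may be only part of what the source reports. "The series", "measured", "known", "first", "only" and "open" are said of these compounds alone.

Compound 1 `O=C(Nc1cccc(-c2oc3cc(-c4ccc(F)cc4)ccc3c(=O)c2O)c1)c1ccccc1F` was tested in a functional assay on MCF7 cells (Homo sapiens) for antiproliferative activity, read by CCK-8 assay, with a stated time of 72 h (a higher number here means a weaker inhibitor, a lower number a stronger inhibitor), and gave 7570 nM. Two close relatives were run alongside it. Compound 2 `O=C(Nc1cccc(-c2oc3cc(-c4ccc(F)cc4)ccc3c(=O)c2O)c1)c1ccc(F)cc1F` gave 13500 nM, and compound 3 `O=C(Nc1cccc(-c2oc3cc(-c4ccc(F)cc4)ccc3c(=O)c2O)c1)c1cccc(F)c1` gave 5770 nM. Among these three numbers compound 1 holds the second highest. Its nearest neighbour is compound 3, with a 1.3-fold lower number from compound 1 to compound 3 (0.12 log units; within the scatter), while compound 2 sits furthest from it, with a 1.8-fold higher number from compound 1 to compound 2 (0.25 log units; within the scatter). For the measured compounds named here, the one step that goes beyond the scatter is a 2.3-fold lower number from compound 2 to compound 3 (0.37 log units; beyond the scatter), a modest move.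

Compound 4 `COc1ccc(C(=O)Nc2cccc(-c3oc4cc(-c5ccc(F)cc5)ccc4c(=O)c3O)c2)c(F)c1` differs from compound 1 in a single place: methoxy in place of hydrogen on an aromatic carbon. Going by the values given here, none of the measured steps concerns a methoxy group; all three vary only the number or position of fluoro groups on the same ring, and they stay within the scatter or just beyond it. On that basis there is no ground to expect a step beyond the scatter in this assay from compound 1 to compound 4, in either direction. Compound 4 is therefore estimated to give 7500 nM, with a range from 3500 nM to 16000 nM. The step this estimate implies is a 1.0-fold lower number from compound 1 to compound 4 (0.00 log units; within the scatter), which is expected to stay within the usual spread.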

Compound 4, half-maximal inhibitory concentration: 20000 nM
Beside the measured number, compound 4's estimate is 2.7-fold (0.43 log units) below it; measured number above the stated range.
By their numbers in this assay, from the lowest: compounds 3, 1, 2 and 4 (each within the scatter of the next, the first and the last beyond it).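

In this assay, the ring position para to a large group and meta to a fluoro group now shows a change beyond the scatter: methoxy in place of hydrogen gives a 2.6-fold higher number from compound 1 to compound 4 (0.42 log units; beyond the scatter), whereas fluoro in place of hydrogen at this position gave only a 1.8-fold higher number from compound 1 to compound 2 (0.25 log units; within the scatter). Methoxy and fluoro at this position are not separated, since methoxy in place of fluoro gives a 1.5-fold higher number from compound 2 to compound 4 (0.17 log units; within the scatter), while the comparison with the 3-fluorophenyl amide gives a 3.5-fold higher number from compound 3 to compound 4 (0.54 log units; beyond the scatter), the widest gap among the four compounds. No measurement shown here explains why methoxy at this position moves the number.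

On these data alone, whether an ethoxy, a hydroxyl or an amine at this position would behave as methoxy does remains open, and so does whether methoxy would give a similar step on a ring without the fluoro group. As far as these compounds go, it is also open whether a methoxy group at another position of this ring would leave the number within the scatter of compound 1 or move it as well.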